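Dichlorophenyl Replacing Phenyl in an Acyl Hydrazide Sulfonamide

The source may hold more compounds than are shown below. What is called first, only, known or untested is meant among the compounds shown, and "the series" means these compounds.

Of the compounds shown here, two have been measured in an assay on cells for inhibition of Amine oxidase [flavin-containing] A (Homo sapiens), read by fluorescence and spectrophotometry, using microsomes, with a stated time of 20 min; on this read-out higher numbers stand for weaker inhibition and lower numbers for stronger inhibition. Compound 1 `NS(=O)(=O)c1ccc(C(=O)NNC(=O)c2ccccc2)cc1` carries a plain phenyl on one carbonyl of its acyl hydrazide; in this assay compound 1 gives 62800 nM. Compound 2 `N#Cc1ccc(-c2nnc(-c3ccc(S(N)(=O)=O)cc3)o2)cc1` is built on a different core, and in this assay compound 2 gives 24300 nM. Of the two numbers, that of compound 1 is the higher, and the gap to compound 2 is described as lying beyond the usual scatter of this assay, so compound 1 is the weaker inhibitor of the pair.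

Compound 3 `NS(=O)(=O)c1ccc(C(=O)NNC(=O)c2ccc(Cl)c(Cl)c2)cc1` has not yet been measured. It differs from compound 1 in one place: 3,4-dichlorophenyl in place of phenyl on a carbonyl carbon. Going by the values given here, no measured pair shows the effect of this change on the present core, so nothing in the data fixes its size or direction. The author nonetheless expects a modest step toward stronger inhibition, of roughly a 2.1-fold lower number from compound 1 to compound 3 (0.32 log units; beyond the scatter), and treats this as an estimate rather than a finding. For compound 3 the expected value in this assay is 30000 nM, with a likely range from 8000 nM to 100000 nM.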

Compound 3, half-maximal inhibitory concentration: 13600 nM
For compound 3 the middle estimate is 2.2-fold (0.34 log units) above the measured one; measured number inside the range.
By their numbers in this assay, from the lowest: compounds 3 and 2 (each within the scatter of the next); then compound 1.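

In this assay, going by these compounds alone, this pair gives the first direct reading of the change on the shared core, with a 4.6-fold lower number from compound 1 to compound 3 (0.66 log units; beyond the scatter) when 3,4-dichlorophenyl takes the place of phenyl on a carbonyl carbon. The step is modest but beyond the usual scatter, so the group at this position does affect the read-out, and the change adds two chlorine atoms while the six-membered aromatic ring, the absence of hydrogen-bond donors and acceptors in the group, and the lack of net charge all stay the same. No measurement available here bears on what lies behind the step.

The two chlorine atoms enter together, so the compounds shown leave open whether a single chlorine on this ring would give all, part or none of the step. They also leave open how a methoxy group or a carboxylic acid on the same ring would read out, and whether the same exchange of phenyl for 3,4-dichlorophenyl would move the number in the same direction on a different core.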